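A few compounds are considered here, and "the series" means these few. Any claim that something is new, unique, unknown or untested is made for them only; others in the source may bear on it.

Compound 1 `CCOc1cc(=O)n(CCCO)c2c1CC(CC=C(C)C)C(C)(C)C2`: 16.6%
Compound 2 `CC(C)=CCC1Cc2c(OCCCNC(=O)c3ccco3)cc(=O)n(CCCO)c2CC1(C)C`: 4.3%
Compound 3 `CC(C)=CCC1Cc2c(OC(=O)Nc3ccc(F)cc3)cc(=O)n(CCCO)c2CC1(C)C`: 0%

All three were tested in a functional assay on PANC-1 cells (Homo sapiens) for inhibition, read by MTT assay, with a stated time of 24 h, tested at 10 uM; a higher number here means more inhibition at the concentration tested (going by the name of the read-out), a lower number less inhibition. Compound 3 stands lowest of the three numbers: a number 4.3 percentage points lower from compound 2 to compound 3 (within the scatter) lies within the scatter, while a number 16.6 percentage points lower from compound 1 to compound 3 (beyond the scatter) lies beyond it.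

Compound 4 `CC(C)=CCC1Cc2c(OC(=O)Nc3ccccc3F)cc(=O)n(CCCO)c2CC1(C)C` keeps everything in compound 3 except one detail: 2-fluorophenyl in place of 4-fluorophenyl on an amide-type nitrogen. Of the measured steps, a number 16.6 percentage points lower from compound 1 to compound 3 (beyond the scatter) and a number 4.3 percentage points lower from compound 2 to compound 3 (within the scatter) concern the arrival of the whole (4-fluorophenyl)carbamoyl unit, not where the fluorine sits on its ring, so none bears directly on this change. With compound 3 already at the floor of this assay, a step of no size beyond the scatter is expected, a number 3 percentage points higher from compound 3 to compound 4 (within the scatter). Compound 4 is estimated at 3%, within 0% to 15%.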

Compound 4, a percentage reported as inhibition, at one concentration (the size of the read-out at that concentration, not a potency): 0%
Estimate against measurement, compound 4: 3 percentage points above; measured number inside the range.
By their numbers in this assay, from the lowest: compounds 3, 4 and 2 (each within the scatter of the next); then compound 1.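

In this assay, no change at the digits printed from compound 3 to compound 4 (within the scatter) shows that moving the fluorine on this ring makes no visible difference at this concentration, though both compounds sit at the floor of the read-out, where any loss of inhibition would stay hidden. The 2-fluorophenyl compound otherwise repeats the picture of compound 3, with a number 4.3 percentage points lower from compound 2 to compound 4 (within the scatter) and a number 16.6 percentage points lower from compound 1 to compound 4 (beyond the scatter) on the same scale. Nothing measured explains these numbers.

On these data alone, what a longer chain in place of ethyl on that oxygen, or an amine on the phenyl ring, would do stays open.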